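Cytotoxicity notes on a piperazine amide series

The source may hold more compounds than are shown below. What is called first, only, known or untested is meant among the compounds shown, and "the series" means these compounds.

Measured compounds in an ADME assay on Vero cells (Chlorocebus sabaeus) for cytotoxicity, read by MTT assay, with a stated time of 72 h; a higher number here means that more compound is tolerated, a lower number that less compound is tolerated:
compound 1 `O=C(CC1CCCCC1)N1CCN(c2nc(=O)c3cc(C(F)(F)F)cc([N+](=O)[O-])c3s2)CC1`: > 125000 nM, a limit of the assay.
compound 2 `CSCC(=O)N1CCN(c2nc(=O)c3cc(C(F)(F)F)cc([N+](=O)[O-])c3s2)CC1`: > 125000 nM, a limit of the assay.
compound 3 `O=C(c1ccccc1F)N1CCN(c2nc(=O)c3cc(C(F)(F)F)cc([N+](=O)[O-])c3s2)CC1`: > 125000 nM, a limit of the assay.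

Compound 3 stands only on a limit in this assay, and the two other values shown beside it are limits as well, as noted in the limit of > 125000 nM in this assay, at which 3 of the 3 values shown sit. The steps between the measured compounds are therefore not readable: a step that the two limits leave unreadable from compound 1 to compound 2, a step that the two limits leave unreadable from compound 1 to compound 3 and a step that the two limits leave unreadable from compound 2 to compound 3.

Compound 4 `O=C(c1ccc(Cl)cc1)N1CCN(c2nc(=O)c3cc(C(F)(F)F)cc([N+](=O)[O-])c3s2)CC1` differs from compound 3 by 4-chlorophenyl in place of 2-fluorophenyl on a carbonyl carbon. Going by the values given here, none of the measured steps gives a readable size, and all three bear on the shared core with a changed amide group, each ending at the same limit. On that basis no step beyond the scatter is expected in this assay from compound 3 to compound 4, so a number no higher from compound 3 to compound 4 (the limit leaves the size open) is the estimated step. For compound 4 the estimated value in this assay is 125000 nM, within 50000 nM to 300000 nM, most likely again reported only as a limit.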

Compound 4, half-maximal cytotoxic concentration: > 125000 nM
Compound 4 ended at the assay's limit (the forecaster's own chance of this, stated with the estimate: 80%); the middle value lies on the limit itself.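

In this assay compound 4 gives > 125000 nM as a limit of the assay. The steps linking compound 4 to compounds 1, 2 and 3 therefore cannot be read: the limit of > 125000 nM in this assay, at which 4 of the 4 values shown sit. The compounds shown leave open how far tolerance extends past that limit, and whether any amide group on the shared core would give a readable value.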